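The source may hold more compounds than are shown below. What is called first, only, known or untested is meant among the compounds shown, and "the series" means these compounds.

Of the compounds shown here, three built on a shared core have been tested in a functional assay on MGC-803 cells (Homo sapiens) for inhibition, read by MTT assay, with a stated time of 72 h; a higher number here means a weaker inhibitor, a lower number a stronger inhibitor. Compound 1, `Fc1ccccc1Cn1cc(CSC(=S)N2CCNCC2)nn1`, gives 19400 nM in this assay. Compound 3, `O=C(OCc1ccccc1)N1CCN(C(=S)SCc2cn(Cc3ccc(F)cc3)nn2)CC1`, gives 17600 nM in this assay. Compound 2, `Cc1cc(=O)oc2cc(OCCn3cc(CSC(=S)N4CCN(C(=O)OC(C)(C)C)CC4)nn3)ccc12`, gives 76900 nM in this assay, the highest of the three numbers. Its nearest neighbour is compound 1, and the gap to compound 1, like the larger gap to compound 3, lies beyond the usual scatter of repeated measurements, so compound 2 is the weakest inhibitor of the three.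

Compound 4, `CC(C)(C)OC(=O)N1CCN(C(=S)SCc2cn(CCOc3ccc4ccc(=O)oc4c3)nn2)CC1`, has not yet been measured in this assay. It differs from compound 2 in a single place: hydrogen in place of methyl on an aromatic carbon. Within the data shown here, no two measured compounds here differ in only one place, so there is no measured step that shows what such a change does in this assay. Trading a methyl for a hydrogen on an aromatic carbon is a small change, and compound 4 is therefore expected to stay close to compound 2, whose reading is 76900 nM, with the step of a 1.1-fold lower number from compound 2 to compound 4 (0.04 log units; within the scatter) expected to fall within the scatter, in no particular direction. The estimate for compound 4 in this assay is 70000 nM, within a range from 30000 nM to 160000 nM.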

Compound 4, half-maximal inhibitory concentration: 67100 nM
Estimate against measurement, compound 4: 1.0-fold (0.02 log units) above; measured number inside the range.
By their numbers in this assay, from the lowest: compounds 3 and 1 (each within the scatter of the next); then compounds 4 and 2 (each within the scatter of the next).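

In this assay, among these compounds, hydrogen in place of methyl on an aromatic carbon is the first change in a single place that can be read directly, and it gives a 1.1-fold lower number from compound 2 to compound 4 (0.06 log units; within the scatter), a step within the usual scatter of repeated measurements. At this carbon, opposite the ring oxygen of the six-membered aromatic ring with 1 oxygen, the methyl can therefore be absent without any difference that this assay can distinguish, so this pair gives no sign that the methyl matters for the reading here. No measurement of any property of these two compounds accompanies the result, so the data offer no explanation for it.

Only methyl and hydrogen have been compared at this carbon, so the compounds shown leave open what a larger or quite different group would do there, such as an ethyl, a methoxy, an amine or a carboxylic acid. They also leave open whether the same exchange would read the same way in compounds that differ from this pair elsewhere in the structure.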